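Series notes: varying the substituent on the shared core

The compounds below may be only part of what the source reports. "The series", "measured", "known", "first", "only" and "open" are said of these compounds alone.

Measured compounds in an in vitro assay on COS-7 cells for displacement of a labelled ligand from prostaglandin D2 receptor 2 (Homo sapiens); a higher number here means a weaker inhibitor, a lower number a stronger inhibitor:
- compound 1 `O=C(O)Cc1sc(Nc2ccccc2)nc1-c1ccc(F)cc1`: compound 1 gives 650 nM
- compound 2 `O=C(O)Cc1sc(Nc2ccc(Cl)cc2)nc1-c1ccc(F)cc1`: compound 2 gives 960 nM
- compound 3 `O=C(O)Cc1sc(-c2ccccc2)nc1-c1ccc(F)cc1`: compound 3 gives 860 nM

Compound 3 sits second highest of the three numbers, with compound 2 nearest and compound 1 furthest, both within the scatter of it. Compound 4 `O=C(O)Cc1sc(Cc2ccccc2Br)nc1-c1ccc(F)cc1` is not yet measured; it differs from compound 3 in one place: 2-bromobenzyl in place of phenyl on an aromatic carbon.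

Within the data shown here, no measured step exchanges an aryl for a benzyl group at this carbon. The steps that touch the same position, a 1.3-fold higher number from compound 1 to compound 3 (0.12 log units; within the scatter) and a 1.1-fold lower number from compound 2 to compound 3 (0.05 log units; within the scatter), are both within the scatter, as is a 1.5-fold higher number from compound 1 to compound 2 (0.17 log units; within the scatter) on the distal ring. Among the measured compounds shown here, the three compounds so far differ little from one another whatever sits on this carbon. A small step is therefore expected in this assay for compound 4, with no clear direction, and the estimate is a 1.0-fold higher number from compound 3 to compound 4 (0.02 log units; within the scatter). Compound 4 is estimated at 900 nM, with a range from 300 nM to 2700 nM.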

Compound 4, half-maximal inhibitory concentration: 700 nM
Estimate against measurement, compound 4: 1.3-fold (0.11 log units) above, and the stated range covers the measured number.
By their numbers in this assay, from the lowest: compounds 1, 4, 3 and 2 (each within the scatter of the next).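

In this assay, 2-bromobenzyl on this carbon gives a number that stays within the scatter of those for phenyl (a 1.2-fold lower number from compound 3 to compound 4 (0.09 log units; within the scatter)), (4-chlorophenyl)amino (a 1.4-fold lower number from compound 2 to compound 4 (0.14 log units; within the scatter)) and anilino (a 1.1-fold higher number from compound 1 to compound 4 (0.03 log units; within the scatter)). This carbon therefore now holds a group of 8 heavy atoms as well as directly attached phenyl, and no step among these four compounds lies beyond the scatter. Nothing available bears on why the numbers stay so close.

The compounds shown leave open what the bromine contributes on its own, and whether a plain benzyl, a longer chain or an amine on this carbon would take the number beyond the scatter. Going by these compounds, the 4-fluorophenyl and carboxymethyl groups are the same throughout, so the effect of changing either also stays open.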